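The source may hold more compounds than are shown below. What is called first, only, known or untested is meant among the compounds shown, and "the series" means these compounds.

Of the compounds shown here, three of a shared core have been measured in a functional assay on U-251 cells (Homo sapiens) for inhibition, read by sulforhodamine B assay, with a stated time of 48 h; on this read-out higher numbers stand for weaker inhibition of growth and lower numbers for stronger inhibition of growth. Compound 1 `COc1cc(-c2nn(-c3cccc(NC(=O)Nc4cc(C(F)(F)F)cc(C(F)(F)F)c4)c3)cc2-c2ccncc2)ccc1Cl` gives 1370 nM. Compound 2 `COc1cc(-c2nn(-c3cccc(NC(=O)Nc4ccc(Cl)c(Cl)c4)c3)cc2-c2ccncc2)ccc1Cl` gives 2470 nM, and compound 3 `O=C(Nc1cccc(-n2cc(-c3ccncc3)c(-c3ccc(Cl)c(O)c3)n2)c1)Nc1ccc(Cl)c(Cl)c1` gives 9680 nM. Among these three numbers compound 2 stands second highest: compound 1 lies nearest, within the scatter, while compound 3 lies furthest, beyond it, as seen in the step of a 3.9-fold higher number from compound 2 to compound 3 (0.59 log units; beyond the scatter), a change of hydrogen in place of methyl on an oxygen on an aromatic ring.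

Compound 4 `COc1cc(-c2nn(-c3cccc(NC(=O)Nc4ccc(Cl)c(C(F)(F)F)c4)c3)cc2-c2ccncc2)ccc1Cl` differs from compound 2 by trifluoromethyl in place of chloro on an aromatic carbon. Within the data shown here, no measured step covers this exact change. Among the measured compounds shown here, the only measured step, from compound 2 to compound 3, alters a different part of the molecule and so does not bear on it. Compound 1 and compound 2 differ on the same ring, yet their values sit within the scatter of each other. On this basis only a step within the scatter is expected, a 1.4-fold lower number from compound 2 to compound 4 (0.14 log units; within the scatter). Compound 4 is therefore estimated at 1800 nM, with a range from 700 nM to 4500 nM.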

Compound 4, concentration for total growth inhibition: 4180 nM
The estimate for compound 4 lay 2.3-fold (0.37 log units) below the measured number; measured number inside the range.
By their numbers in this assay, from the lowest: compounds 1, 2 and 4 (each within the scatter of the next, the first and the last beyond it); then compound 3.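

In this assay, the exchange of 3,4-dichlorophenyl for 4-chloro-3-(trifluoromethyl)phenyl gives a 1.7-fold higher number from compound 2 to compound 4 (0.23 log units; within the scatter), so at this place, ortho to a chloro group and meta to a large group, trifluoromethyl with its 4 heavy atoms stands in for chloro with its 1 heavy atom without a difference that can be told from the scatter. Among these compounds, the earlier compounds held no step that changes this one position alone, so this is the first direct reading of it. Nothing measured here offers an explanation for how little the number moves.

Only chloro and trifluoromethyl are shown at this position, so it remains open how a nitrile, a methoxy group or an amine would fare there. Going by these compounds, it also remains open whether hydrogen in place of methyl on the oxygen would have the same effect in compound 4 as it has in compound 2.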